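A few compounds are considered here, and "the series" means these few. Any claim that something is new, unique, unknown or untested is made for them only; others in the source may bear on it.

In a functional assay on MDA-MB-231 cells (Homo sapiens) for antiproliferative activity, with a stated time of 4 days (a higher number here means a weaker inhibitor, a lower number a stronger inhibitor), compound 1 `COc1ccc(-c2[nH]c3cc(OC)ccc3c2C=O)cc1` gives 35 nM. In this assay compound 2 `COc1ccc(-c2[nH]c3ccc(C(C)C)cc3c2C=O)cc1` gives 29 nM. These two numbers lie within the usual scatter of repeated measurements, so neither compound can be ranked above the other, and compound 2 stands level with compound 1. The next compound, compound 3 `CCCCCCc1ccc2[nH]c(-c3ccc(OC)cc3)c(C=O)c2c1`, has not yet been measured. It matches compound 2 except for one change: hexyl in place of isopropyl on an aromatic carbon. Among the compounds with values here, no pair of measured compounds differs at only one place, so the data give no direct guide to what a longer chain does here, and any expectation is uncertain. A moderate loss of activity seems more likely than a gain or a collapse. The expected change is a 3.4-fold higher number from compound 2 to compound 3 (0.54 log units; beyond the scatter), towards a weaker inhibitor and modestly beyond the scatter. For compound 3 the estimated value is 100 nM, with an expected range of 30 nM to 350 nM.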

Compound 3, half-maximal inhibitory concentration: 7.4 nM
Estimate against measurement, compound 3: 14-fold (1.13 log units) above; the measured number lies below the stated range.
By their numbers in this assay, from the lowest: compound 3; then compounds 2 and 1 (each within the scatter of the next).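

Within the data shown here, the step from isopropyl to hexyl is the first comparison here in which only one place changes, and in this assay it gives a 3.9-fold lower number from compound 2 to compound 3 (0.59 log units; beyond the scatter). So this aromatic carbon of the shared core does more than tolerate a longer chain: with hexyl in place of isopropyl, compound 3 is the stronger inhibitor of the pair. No measurement at hand says why the number falls with this change.

A single step cannot show how activity depends on chain length, so a butyl or an octyl chain at this carbon could land on either side of compound 3. Nor does it show whether the hexyl gain depends on an all-carbon chain, which a chain ending in an amine or a carboxylic acid would test.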